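A few compounds are considered here, and "the series" means these few. Any claim that something is new, unique, unknown or untested is made for them only; others in the source may bear on it.

Among the compounds with values here, compound 1 `COc1ccc(-c2ccc(-c3ccc(C(=N)N)cc3)s2)cc1` is one of two compounds measured in a functional assay on SF-539 cells (Homo sapiens) for inhibition, read by sulforhodamine B assay, with a stated time of 48 h (a lower number here means a stronger inhibitor of growth, a higher number a weaker inhibitor of growth), and compound 1 gives 160 nM, the lower of the two numbers. Compound 2 `N=C(N)c1ccc(-c2ccc(-c3cc(Cl)cc(Cl)c3)s2)cc1` gives 1970 nM in this assay, a gap beyond the usual scatter. The change leading to compound 3 `N=C(N)c1ccc(-c2ccc(-c3ccc(F)cc3)s2)cc1` is fluoro in place of methoxy on an aromatic carbon. Within the data shown here, no two measured compounds differ in only one place, so the size of such a step cannot be read from the data. A modest weakening is expected, and the step is estimated as a 2.0-fold higher number from compound 1 to compound 3 (0.30 log units; within the scatter). Compound 3 is therefore expected to give 320 nM in this assay, most likely between 110 nM and 950 nM.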

Compound 3, concentration for 50% growth inhibition: 1620 nM
Compound 3: the middle estimate sits 5.1-fold (0.70 log units) below what was measured; the measured number lies above the stated range.
By their numbers in this assay, from the lowest: compound 1; then compounds 3 and 2 (each within the scatter of the next).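

In this assay, putting fluoro in place of methoxy on this aromatic carbon, para to a large group, gives a 10-fold higher number from compound 1 to compound 3 (1.01 log units; beyond the scatter). Within the data shown here, this is the first step here that changes only one place, and it shows that growth inhibition responds strongly to the group at this position, even when one small substituent replaces another. Nothing measured here accounts for this step. On these data alone, it remains open whether a hydroxyl, an ethoxy or an amine at this position would keep the low number of compound 1.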